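The compounds below may be only part of what the source reports. "The series", "measured", "known", "first", "only" and "open" are said of these compounds alone.

Measured so far in an ADME assay on HeLa cells (Homo sapiens) for cytotoxicity, with a stated time of 72 h; a lower number here means that less compound is tolerated, a higher number that more compound is tolerated:
- compound 1 `CC(C)C[C@H](N)C(=O)Nc1ccc(NC(=O)/C=C/c2ccc(-c3ccc([N+](=O)[O-])cc3)o2)cc1C(=O)c1ccccc1`: > 83000 nM (a limit of the assay, not a number)
- compound 2 `CC(C)C[C@@H](N)C(=O)Nc1ccc(NC(=O)/C=C/c2ccc(-c3ccc([N+](=O)[O-])cc3)o2)cc1C(=O)c1ccccc1`: 47800 nM

Within the data shown here, compound 2 holds the only actual number in this assay, so it has no numerical comparator. Among the measured compounds shown here, the single measured step is an at least 1.7-fold lower number from compound 1 to compound 2 (0.23 log units; that floor lies within the scatter). That step rests on the limit of > 83000 nM in this assay, at which 1 of the 2 values shown sits, and on (the fact that compounds 1 and 2 differ only in the configuration as drawn), and it gives no size for a change in the chain.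

Compound 3 `CC[C@H](C)[C@H](N)C(=O)Nc1ccc(NC(=O)/C=C/c2ccc(-c3ccc([N+](=O)[O-])cc3)o2)cc1C(=O)c1ccccc1` carries 1-amino-2-methylbutyl in place of 1-amino-3-methylbutyl on a carbonyl carbon, with the same atoms joined differently. For the measured compounds named here, no measured step covers this kind of change, and the one step available stays within the scatter, so no shift beyond the scatter is expected in this assay. The expected step is a 1.2-fold higher number from compound 2 to compound 3 (0.06 log units; within the scatter), with no firm direction. For compound 3 the estimated value is 55000 nM, with an expected range of 28000 nM to 105000 nM.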

Compound 3, half-maximal cytotoxic concentration: > 83000 nM
Compound 3: no number, only a limit (the forecaster's own chance of this, stated with the estimate: 30%); middle value at least 1.5-fold (0.17 log units) from the limit.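

In this assay, moving the methyl branch to give 1-amino-2-methylbutyl in place of 1-amino-3-methylbutyl on a carbonyl carbon gives an at least 1.7-fold higher number from compound 2 to compound 3 (0.23 log units; that floor lies within the scatter). Compound 3 gives > 83000 nM, a limit of the assay and not a number, so this change has a floor but no size, and its floor does not separate it from the scatter. The step between compound 1 and compound 3 cannot be read, and the series shown mostly stops at one point: the limit of > 83000 nM in this assay, at which 2 of the 3 values shown sit.

Going by these compounds, whether the number at this position responds to the branch itself or to the configuration drawn on the 1-amino-2-methylbutyl chain remains open. Also open, on these data alone, is what a longer chain, or a carboxylic acid in place of the branched alkyl part, would give in this assay.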